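The source may hold more compounds than are shown below. What is called first, only, known or untested is meant among the compounds shown, and "the series" means these compounds.

Measured in a functional assay on A549 cells (Homo sapiens) for inhibition, read by sulforhodamine B assay, with a stated time of 72 h; a lower number here means a stronger inhibitor of growth, a higher number a weaker inhibitor of growth:
- compound 1 `O=C(O)/C=C/c1ccncc1-c1ccc2ccccc2c1`: > 10000 nM (a limit)
- compound 2 `COC1CN(C(=O)/C=C/c2ccncc2-c2ccc3ccccc3c2)C1`: > 10000 nM (a limit)

Compound 2 has no number in this assay, only the limit > 10000 nM. Compound 3 `COC(=O)/C=C/c1ccncc1-c1ccc2ccccc2c1` carries methoxy in place of 3-methoxyazetidin-1-yl on a carbonyl carbon. Among the measured compounds shown here, the one measured step at this carbonyl carbon is a step that the two limits leave unreadable from compound 1 to compound 2, and it gives no size. For the measured compounds named here, the series so far shows only (the limit of > 10000 nM in this assay, at which 2 of the 2 values shown sit). No clear direction is therefore expected, and the expected change is a number no higher from compound 2 to compound 3 (the limit leaves the size open). Compound 3 is estimated at 10000 nM, with an expected range of 3000 nM to 20000 nM.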

Compound 3, concentration for 50% growth inhibition: 760 nM
Compound 3: the middle estimate sits 13-fold (1.12 log units) above what was measured, outside the stated range (below it).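

At the carbonyl carbon, the group attached decides whether a number can be read at all in this assay: methoxy in place of 3-methoxyazetidin-1-yl gives an at least 13-fold lower number from compound 2 to compound 3 (1.11 log units; beyond the scatter), and methyl in place of hydrogen on the oxygen gives an at least 13-fold lower number from compound 1 to compound 3 (1.11 log units; beyond the scatter). Small changes at this one carbonyl carbon are thus enough to move the series off its limit. Compound 1 and compound 2 remain limits rather than numbers, and the step between them cannot be read: the limit of > 10000 nM in this assay, at which 2 of the 3 values shown sit.

From the compounds shown here alone, whether an ethyl ester or a longer chain on the oxygen holds the level of compound 3 stays open. So does whether a simple primary amide at this carbonyl carbon behaves like compound 3 or like compound 2.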